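The source may hold more compounds than are shown below. What is called first, only, known or untested is meant among the compounds shown, and "the series" means these compounds.

Working notes on the series. All three measured compounds share one core and differ only in the aryl group sitting on the ring carbon next to the ring nitrogen of the fused system. Compound 1 `COc1cc2c(Oc3ccc(NC(=O)c4cc(-c5ccccc5)nc5ccccc45)cc3F)ccnc2cc1OCCCN1CCCCC1` carries an unsubstituted phenyl there; in a functional assay on MKN-45 cells (Homo sapiens) for cytotoxicity, read by MTT assay, with a stated time of 72 h (a higher number here means a weaker inhibitor, a lower number a stronger inhibitor), compound 1 gives 15 nM. Compound 2 `COc1ccc(-c2cc(C(=O)Nc3ccc(Oc4ccnc5cc(OCCCN6CCCCC6)c(OC)cc45)c(F)c3)c3ccccc3n2)cc1` carries a 4-methoxyphenyl, and in this assay compound 2 gives 210 nM. Compound 3 `COc1cccc(-c2cc(C(=O)Nc3ccc(Oc4ccnc5cc(OCCCN6CCCCC6)c(OC)cc45)c(F)c3)c3ccccc3n2)c1` carries a 3-methoxyphenyl, and in this assay compound 3 gives 360 nM, the highest number of the three: one of its steps is a 1.7-fold higher number from compound 2 to compound 3 (0.23 log units; within the scatter), within the scatter, while the other is a 24-fold higher number from compound 1 to compound 3 (1.38 log units; beyond the scatter), well beyond it.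

The step to compound 4 `COc1cc2c(Oc3ccc(NC(=O)c4cc(-c5ccc(F)cc5)nc5ccccc45)cc3F)ccnc2cc1OCCCN1CCCCC1` is 4-fluorophenyl in place of 3-methoxyphenyl on an aromatic carbon. Among the compounds with values here, no measured step swaps a methoxy for a fluorine directly; the steps that bear on it are the two methoxy additions onto the phenyl, a 14-fold higher number from compound 1 to compound 2 (1.15 log units; beyond the scatter) and a 24-fold higher number from compound 1 to compound 3 (1.38 log units; beyond the scatter), which were both large and of similar size at either position. Taking the methoxy off again is therefore expected to give back most of that loss, with the effect of the fluorine left open. The expected step is a 10-fold lower number from compound 3 to compound 4 (1.01 log units; beyond the scatter), toward a lower number. Compound 4 is estimated at 35 nM, within 10 nM to 130 nM.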

Compound 4, half-maximal inhibitory concentration: 28 nM
For compound 4 the middle estimate is 1.3-fold (0.10 log units) above the measured one; the measured number falls inside the stated range.
By their numbers in this assay, from the lowest: compounds 1 and 4 (each within the scatter of the next); then compounds 2 and 3 (each within the scatter of the next).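

In this assay a fluorine on the phenyl leaves the number where it was: a 1.9-fold higher number from compound 1 to compound 4 (0.27 log units; within the scatter) is within the scatter, so this position accepts a 4-fluorophenyl as readily as an unsubstituted phenyl. The direct exchange at the same ring position, a 7.5-fold lower number from compound 2 to compound 4 (0.88 log units; beyond the scatter), is beyond the scatter, and a 13-fold lower number from compound 3 to compound 4 (1.11 log units; beyond the scatter) is a large step in the same direction, which recovers almost all of what the methoxy additions cost. Among the four compounds, then, the loss goes with methoxy and not with substitution of the phenyl as such, and no listed compound goes against this, although it rests on a single fluoro example.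

Nothing among the data gives a reason for the gap between the methoxy and the fluoro compounds. Still open, on these data alone, is whether the tolerance holds for a 3-fluorophenyl, which would separate the effect of the group from that of its position, and whether a chloro, an amine or a carboxylic acid on the phenyl would stay with compound 1 and compound 4 or fall with compound 2 and compound 3.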